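The source may report more compounds than this note shows. Statements on the series, on what has been measured and on what is new or still open speak of the compounds shown alone.

In an ADME assay on HeLa cells (Homo sapiens) for cytotoxicity, read by MTT assay (a lower number here means a stronger inhibitor, a higher number a weaker inhibitor), compound 1 `COc1ccc(C[C@H]2COC(=O)[C@@H]2Cc2ccc(OCC(=O)N3CCCC3)c(OC)c2)cc1OC` gives >= 600000 nM, and this is a limit of the assay, not a number. Among the compounds with values here, compound 2 `COc1ccc(C[C@H]2COC(=O)[C@@H]2Cc2ccc(OCc3cn(Cc4ccccc4Cl)nn3)c(OC)c2)cc1OC` gives 84500 nM, the only true number available, so it stands alone as the point of reference. Compound 3 `COc1ccc(C[C@H]2COC(=O)[C@@H]2Cc2ccc(OCc3cn(-c4cccc(Cl)c4)nn3)c(OC)c2)cc1OC` differs from compound 2 in one place, with 3-chlorophenyl in place of 2-chlorobenzyl on an aromatic nitrogen of a five-membered aromatic ring with 3 nitrogen (3-chlorophenyl in place of 2-chlorobenzyl on an aromatic nitrogen). Both groups hold one six-membered aromatic ring of carbon only and carry no net charge. Within the data shown here, no measured step between compounds is available to size such a change in this assay, so the expectation starts from compound 2 at 84500 nM. A shift no larger than the usual scatter is expected, with no firm direction, and the estimated step is a 1.1-fold higher number from compound 2 to compound 3 (0.03 log units; within the scatter). For compound 3 the expected value is 90000 nM, within an estimated range of 30000 nM to 270000 nM.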

Compound 3, half-maximal inhibitory concentration: 493000 nM
Estimate against measurement, compound 3: 5.5-fold (0.74 log units) below, outside the stated range (above it).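

In this assay, the step of a 5.8-fold higher number from compound 2 to compound 3 (0.77 log units; beyond the scatter) shows that the number at this aromatic nitrogen of a five-membered aromatic ring with 3 nitrogen responds to the change from 2-chlorobenzyl to 3-chlorophenyl, even though both groups hold one six-membered aromatic ring of carbon only and carry no net charge. Within the data shown here, the step of an at least 1.2-fold lower number from compound 1 to compound 3 (0.08 log units; that floor lies within the scatter) has a floor within the scatter, so it gives no order for that pair. Compound 1 stands at a limit of the assay, not at a number: the limit of >= 600000 nM in this assay, at which 1 of the 3 values shown sits.

The change alters both the benzyl carbon and the place of the chlorine at once, so the compounds shown do not tell which of the two goes with the higher number. Plain phenyl, 2-chlorophenyl and 3-chlorobenzyl on that nitrogen remain open, as does an amine on the aromatic ring.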